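Imidazole substitution pattern on the shared core

The source may report more compounds than this note shows. Statements on the series, on what has been measured and on what is new or still open speak of the compounds shown alone.

Compound 3 `CCCCc1nc(CN2CCN(c3cccc4[nH]c(-c5ccc(C(C)(C)C)cc5)nc34)CC2)cn1C` gives 58 nM in an assay on isolated protein for displacement of a labelled ligand from Gonadotropin-releasing hormone receptor (Rattus norvegicus) (on this read-out lower numbers stand for stronger inhibition and higher numbers for weaker inhibition), the second highest of the three numbers seen so far; its nearest neighbour is compound 2 `CCCCn1cnc(CN2CCN(c3cccc4[nH]c(-c5ccc(C(C)(C)C)cc5)nc34)CC2)c1C` at 49 nM, and its furthest is compound 1 `Cn1cnc(CN2CCN(c3cccc4[nH]c(-c5ccc(C(C)(C)C)cc5)nc34)CC2)c1` at 98 nM, both within the scatter of compound 3. Compound 4 `CCCn1c(CC)nc(C)c1CN1CCN(c2cccc3[nH]c(-c4ccc(C(C)(C)C)cc4)nc23)CC1` differs from compound 3 by 2-ethyl-4-methyl-1-propyl-1H-imidazol-5-yl in place of 2-butyl-1-methyl-1H-imidazol-4-yl on a saturated chain carbon bound to an amine nitrogen in a ring. Going by the values given here, the steps that bear on this change are the earlier rearrangements of the same ring: a 2.0-fold lower number from compound 1 to compound 2 (0.30 log units; within the scatter) and a 1.2-fold higher number from compound 2 to compound 3 (0.07 log units; within the scatter), with a 1.7-fold lower number from compound 1 to compound 3 (0.23 log units; within the scatter) alongside; none leaves the scatter. A further move of this kind is therefore expected to give no step beyond the scatter, a 1.0-fold higher number from compound 3 to compound 4 (0.01 log units; within the scatter). Compound 4 is accordingly estimated at 60 nM, with a range of 25 nM to 150 nM.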

Compound 4, half-maximal inhibitory concentration: 120 nM
Compound 4: the middle estimate sits 2.0-fold (0.30 log units) below what was measured, within the range that was stated.
By their numbers in this assay, from the lowest: compounds 2, 3, 1 and 4 (each within the scatter of the next, the first and the last beyond it).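

In this assay, going by these compounds alone, 2-ethyl-4-methyl-1-propyl-1H-imidazol-5-yl gives the first steps at this position beyond the scatter, both modest (a 2.1-fold higher number from compound 3 to compound 4 (0.32 log units; beyond the scatter); a 2.4-fold higher number from compound 2 to compound 4 (0.39 log units; beyond the scatter)), so the substitution pattern on this imidazole is not neutral here. The same group stays within the scatter of the 1-methyl-1H-imidazol-4-yl of compound 1 (a 1.2-fold higher number from compound 1 to compound 4 (0.09 log units; within the scatter)). Nothing available bears on why these steps arise.

The ring attachment and the substituents change together in compound 4, so the step cannot be assigned to either one. Going by these compounds, the effect of a carboxylic acid or an amine on the imidazole chain remains open.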